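Amide replacements on a shared core: tolerability notes

The source may report more compounds than this note shows. Statements on the series, on what has been measured and on what is new or still open speak of the compounds shown alone.

Measured so far:
Compound 1 `Cn1c(-c2ccccc2)cnc1NC(=O)c1ncc[nH]1`: in a toxicity assay on THP-1 cells (Homo sapiens) for inhibition (a higher number here means that more compound is tolerated, a lower number that less compound is tolerated), compound 1 gives > 100000 nM, a limit of the assay.
Compound 2 `Cn1c(-c2ccccc2)cnc1NC(=O)C1CCCCC1`: in this assay compound 2 gives > 100000 nM, also a limit.

Compound 2 therefore stands at the limit, as does compound 1 (the limit of > 100000 nM in this assay, at which 2 of the 2 values shown sit). Among the compounds with values here, the one measured step, a step that the two limits leave unreadable from compound 1 to compound 2, cannot be read because both values are limits.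

Compound 3 `Cn1c(-c2ccccc2)cnc1NC(=O)c1cccc(Br)c1` differs from compound 2 by 3-bromophenyl in place of cyclohexyl on a carbonyl carbon. No readable step bears on this change, so nothing measured argues for movement beyond the scatter. Compound 3 is expected to stay at the limit, with the step of a number no higher from compound 2 to compound 3 (the limit leaves the size open) expected to be none beyond scatter. The estimate for compound 3 is 100000 nM, ranging from 40000 nM to 300000 nM.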

Compound 3, half-maximal cytotoxic concentration: > 50000 nM
Compound 3: a limit, no number; the forecaster's own chance of this, stated with the estimate: 70%; the middle value is on the limit's open side.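

Compound 3 is also a limit, so the steps among compound 1, compound 2 and compound 3 cannot be read. The compounds shown leave open how far any of these amide replacements shifts tolerated concentration in this assay.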